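Swapping the whole aryl group on the amine of compound 1

A few compounds are considered here, and "the series" means these few. Any claim that something is new, unique, unknown or untested is made for them only; others in the source may bear on it.

In a functional assay on HCC827 cells (Homo sapiens) for inhibition, read by MTT assay, with a stated time of 48 h, tested at 10 uM (on this read-out higher numbers stand for more inhibition at the one concentration tested (going by the name of the read-out) and lower numbers for less inhibition), the three measured compounds gave these results:
compound 1 `COc1cc(NC(=O)Nc2cc(Nc3cc(F)ccc3OC)ncn2)cc(OC)c1`: 59%
compound 2 `COc1cc(NC(=O)Nc2cc(Nc3cc(C(F)(F)F)ccc3OC)ncn2)cc(OC)c1`: 59.7%
compound 3 `COc1ccc(Br)cc1Nc1cc(NC(=O)Nc2c(Cl)cccc2Cl)ncn1`: 53%

Compound 1 stands second highest of the three, yet all three lie within the scatter of one another, so none can be called stronger than the others. Compound 4 `COc1cc(NC(=O)Nc2cc(Nc3ccc(OC)c(C)c3)ncn2)cc(OC)c1` differs from compound 1 in one place: 4-methoxy-3-methylphenyl in place of 5-fluoro-2-methoxyphenyl on a nitrogen on an aromatic ring. Going by the values given here, the only measured step, a number 0.7 percentage points higher from compound 1 to compound 2 (within the scatter), changed a single group on that same ring and stayed within the scatter; no measured step exchanges the whole ring as here. With that, and all three results close together, the step of a number 4 percentage points lower from compound 1 to compound 4 (within the scatter) is expected to stay within the scatter. Compound 4 is therefore estimated at 55%, with a range from 40% to 68%.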

Compound 4, a percentage reported as inhibition, at one concentration (the size of the read-out at that concentration, not a potency): 48.3%
For compound 4 the middle estimate is 6.7 percentage points above the measured one; the measured number falls inside the stated range.
By their numbers in this assay, from the lowest: compounds 4, 3, 1 and 2 (each within the scatter of the next, the first and the last beyond it).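

In this assay, going by these compounds alone, exchanging the whole aryl group on the nitrogen gives a number 10.7 percentage points lower from compound 1 to compound 4 (beyond the scatter), the first step here to pass the scatter, so this position does respond to what it carries. The entering and leaving groups match in heavy-atom count and in hydrogen-bond acceptors, so those counts do not separate them.

From the compounds shown here alone, whether the fall follows the added methyl, the lost fluoro or the different methoxy placing stays open, as does the result of an amine or a carboxylic acid on this ring. No evidence at hand gives a reason for the step.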